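The source may report more compounds than this note shows. Statements on the series, on what has been measured and on what is new or still open speak of the compounds shown alone.

Compound 1, `CCCCCCCCc1cn(C(c2ccccc2)c2cc3cc(Br)ccc3nc2OC)nn1`, and compound 2, `CCCCCc1cn(C(c2ccccc2)c2cc3cc(Br)ccc3nc2OC)nn1`, share one core and differ only in the length of a saturated chain. In an ADME assay on HeLa cells (Homo sapiens) for cytotoxicity, read by sulforhodamine B assay, with a stated time of 48 h, tested at 10 uM (a lower number here means less inhibition, a higher number more inhibition at the concentration tested (going by the name of the read-out)), compound 1 gives 0.1%, and in the same assay compound 2 gives -9.81%, which is the lowest of the two numbers shown; the step of a number 9.9 percentage points lower from compound 1 to compound 2 (within the scatter) is within the scatter, so the two values cannot be told apart. Compound 3, `COc1nc2ccc(Br)cc2cc1C(c1ccccc1)n1cc(CO)nn1`, carries the change (hydroxy in place of butyl on a saturated chain carbon bound to an aromatic carbon). Within the data shown here, the only measured step that bears on this change is a number 9.9 percentage points lower from compound 1 to compound 2 (within the scatter), which shortened the same chain without moving the read-out beyond the scatter; it says nothing about a hydroxy group, which no measured compound here carries. Among the measured compounds shown here, with both measured values sitting near zero and the one relevant step flat, no movement beyond the scatter is expected in this assay for compound 3, an expected step of a number 6.8 percentage points higher from compound 2 to compound 3 (within the scatter). Compound 3 is therefore estimated at -3%, with a range from -20% to 14%.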

Compound 3, a percentage reported as inhibition, at one concentration (the size of the read-out at that concentration, not a potency): 0.25%
The estimate for compound 3 lay 3.3 percentage points below the measured number; the measured number falls inside the stated range.
By their numbers in this assay, from the lowest: compounds 2, 1 and 3 (each within the scatter of the next, the first and the last beyond it).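

Swapping pentyl for hydroxymethyl at this position in this assay gives a number 10.1 percentage points higher from compound 2 to compound 3 (beyond the scatter), so a hydroxy group on the carbon bound to the aromatic ring can be told apart from the pentyl chain, though only modestly. The same hydroxy compared with the longest chain here gives a number 0.2 percentage points higher from compound 1 to compound 3 (within the scatter), so the change does not separate compound 3 from compound 1, and the hydroxy group's effect depends on which chain it is compared with. The three compounds therefore show that this position accepts a short chain end bearing a hydrogen-bond donor and acceptor without any large shift in the read-out, but nothing available here explains the modest difference from compound 2.

The compounds shown leave open whether an amine, a carboxylic acid or a chain longer than that of compound 1 at this position would move the read-out further. They also leave open whether the small gap between compound 2 and compound 3 would hold up on repeated measurement, as it lies close to the usual scatter of this read-out.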